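Swapping the amide aryl group: from methylphenyl to pyrazinyl

The compounds below may be only part of what the source reports. "The series", "measured", "known", "first", "only" and "open" are said of these compounds alone.

Of the compounds shown here, three sharing one core have been tested in a functional assay on the whole organism for inhibition, with Rattus norvegicus as the target, read by cytopathic effect and paw edema, at a dose of 100 mg/kg by the oral route; on this read-out higher numbers stand for more inhibition at the one dose given (going by the name of the read-out) and lower numbers for less inhibition. Compound 1 `O=C(Nc1ccccn1)c1c(O)c2cccnc2n(-c2ccccc2)c1=O` carries a pyridin-2-yl group on the amide nitrogen and gives 14.6%. Compound 2 `O=C(Nc1ccccc1)c1c(O)c2cccnc2n(-c2ccccc2)c1=O` carries a plain phenyl there and gives -15%. Compound 3 `Cc1ccc(NC(=O)c2c(O)c3cccnc3n(-c3ccccc3)c2=O)cc1` carries a 4-methylphenyl and gives 2.2%, which places it second of the three, lying below compound 1 and above compound 2, with both gaps beyond the usual scatter.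

Compound 4 `O=C(Nc1cnccn1)c1c(O)c2cccnc2n(-c2ccccc2)c1=O` is the next candidate. The change from compound 3 is pyrazin-2-yl in place of 4-methylphenyl on an amide-type nitrogen.

Going by the values given here, two measured steps bear on this. Replacing phenyl with pyridin-2-yl raised inhibition in this assay, seen as a number 29.6 percentage points lower from compound 1 to compound 2 (beyond the scatter) read in reverse; replacing 4-methylphenyl with pyridin-2-yl also raised it, seen as a number 12.4 percentage points lower from compound 1 to compound 3 (beyond the scatter) read in reverse. A pyrazin-2-yl group resembles pyridin-2-yl more than it resembles either carbon-only ring, so the step into compound 4 is expected to run upward by a modest amount, a number 9.8 percentage points higher from compound 3 to compound 4 (within the scatter), rather than stay within the scatter.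

The estimate for compound 4 in this assay is therefore 12%, with an expected range from -6% to 28%.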

Compound 4, a percentage reported as inhibition, in the whole organism at one dose (the size of the read-out at that dose, not a potency): 21.2%
The estimate for compound 4 lay 9.2 percentage points below the measured number; low and high end bracket the measured number.
By their numbers in this assay, from the lowest: compound 2; then compound 3; then compounds 1 and 4 (each within the scatter of the next).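

In this assay, going by these compounds alone, pyrazin-2-yl on the amide-type nitrogen reads clearly better than either carbon-only ring, with a number 19 percentage points higher from compound 3 to compound 4 (beyond the scatter) against 4-methylphenyl and a number 36.2 percentage points higher from compound 2 to compound 4 (beyond the scatter) against phenyl, the only large step so far. Pyrazin-2-yl and pyridin-2-yl, however, are not separated, since the swap gives a number 6.6 percentage points higher from compound 1 to compound 4 (within the scatter) and so cannot be told apart from repeat variation. A second ring containing nitrogen therefore behaves like the first, and among these four compounds both nitrogen-containing rings stand above both carbon-only rings, with no compound going against that split.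

Nothing shown here explains why the rings containing nitrogen read differently from the carbon-only ones. Also open is whether a saturated ring such as piperidine, or a pyridin-2-yl ring carrying an amine or a carboxylic acid, would hold this level of inhibition, and how any of these compounds would behave at other doses, given that each number comes from a single dose.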